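Trimming the aryl group of compound 3

A few compounds are considered here, and "the series" means these few. Any claim that something is new, unique, unknown or untested is made for them only; others in the source may bear on it.

Of the compounds shown here, three sharing one core have been tested in a functional assay on MCF7 cells (Homo sapiens) for antiproliferative activity; a lower number here means a stronger inhibitor, a higher number a weaker inhibitor. There, compound 1 (`Cc1c(OC2CCN(C)CC2)ccc2cc(NC(=O)c3ccc(O)c(CCC(C)C)c3)c(=O)oc12`) gives 1250 nM, compound 2 (`Cc1c(OC2CCN(C)CC2)ccc2cc(NC(=O)c3ccccc3)c(=O)oc12`) gives 11700 nM and compound 3 (`CC(=O)Oc1ccc(C(=O)Nc2cc3ccc(OC4CCN(C)CC4)c(C)c3oc2=O)cc1Cl`) gives 1610 nM. Compound 3 thus sits level with compound 1, within the usual scatter, and well apart from compound 2. Among the compounds with values here, the only single change measured so far, 4-acetoxy-3-chlorophenyl in place of phenyl on a carbonyl carbon, gave a 7.3-fold lower number from compound 2 to compound 3 (0.86 log units; beyond the scatter).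

The next compound, compound 4 (`Cc1c(OC2CCN(C)CC2)ccc2cc(NC(=O)c3ccc(O)cc3)c(=O)oc12`), carries 4-hydroxyphenyl in place of 4-acetoxy-3-chlorophenyl on a carbonyl carbon. Within the data shown here, no measured step covers this change directly, so the evidence is indirect. The group in compound 4 stands partway back towards the plain phenyl of compound 2, which gives 11700 nM. Compound 1 also has a hydroxy group on its phenyl ring and gives 1250 nM, but it has a 3-methylbutyl chain there too, which compound 4 lacks. Part of the earlier gain is therefore expected to be lost, though probably not all of it. The expected change is a 3.0-fold higher number from compound 3 to compound 4 (0.47 log units; beyond the scatter). For compound 4 the estimated value in this assay is 4800 nM, with an expected range of 1700 nM to 13000 nM.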

Compound 4, half-maximal inhibitory concentration: 1430 nM
Compound 4: the middle estimate sits 3.4-fold (0.53 log units) above what was measured, outside the stated range (below it).
By their numbers in this assay, from the lowest: compounds 1, 4 and 3 (each within the scatter of the next); then compound 2.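

The plain phenyl of compound 2 and the 4-hydroxyphenyl of compound 4 differ by one group, and hydroxy in place of hydrogen on an aromatic carbon alone gives an 8.2-fold lower number from compound 2 to compound 4 (0.91 log units; beyond the scatter) in this assay. The larger groups on this ring add nothing that can be told apart from that single hydroxy group: exchanging the 4-acetoxy-3-chlorophenyl for 4-hydroxyphenyl gives a 1.1-fold lower number from compound 3 to compound 4 (0.05 log units; within the scatter), and hydrogen in place of isopentyl gives a 1.1-fold higher number from compound 1 to compound 4 (0.06 log units; within the scatter), both within the scatter. So, among these four compounds, the aryl group on the carbonyl carbon can be trimmed to 4-hydroxyphenyl with no measurable loss, although nothing measured here explains why the hydroxy group has this effect.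

From the compounds shown here alone, it remains open whether the hydroxy group itself is needed, or whether a methoxy group or an amine in its place would give a similar number. Going by these compounds, compound 3 carries its chlorine and acetoxy group together, so what each does alone on this ring also remains open, as does whether a 3-chlorophenyl group would differ from the plain phenyl of compound 2.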